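The source may report more compounds than this note shows. Statements on the series, on what has been measured and on what is new or still open speak of the compounds shown alone.

Measured so far:
- compound 1 `CC(C)c1c(C(=O)NCC2CCCCC2)nn(-c2ccc(F)cc2)c1OC[C@@H](O)C[C@@H](O)CC(=O)O`: "not determined" (no result reported)
- compound 2 `CC(C)c1c(C(=O)N2CCC[C@H](N3CCC4C=CC=CC4C3)C2)nn(-c2ccc(F)cc2)c1CC[C@@H](O)C[C@@H](O)CC(=O)O`: 1720 nM

In a functional assay on L6 cells (Rattus norvegicus) for inhibition (a higher number here means a weaker inhibitor, a lower number a stronger inhibitor), compound 1 stands at "not determined" (no result reported), so it has no number of its own and cannot be ranked against anything. For the measured compounds named here, the only number nearby is that of compound 2, at 1720 nM, and this compound differs from compound 1 in more than one place.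

Compound 3 `Cc1cccc(CNC(=O)c2nn(-c3ccc(F)cc3)c(OC[C@@H](O)C[C@@H](O)CC(=O)O)c2C(C)C)c1` keeps the core of compound 1 and changes one group: 3-methylphenyl in place of cyclohexyl on a saturated chain carbon bound to an amide-type nitrogen. In words, 3-methylphenyl stands in place of cyclohexyl on a saturated chain carbon bound to an amide-type nitrogen. Going by the values given here, no measured step shows what such a swap does, so the expectation is a step no larger than the usual scatter in this assay, with no favoured direction. The estimate therefore stays broad and leans on compound 2 at 1720 nM. For compound 3 the expected value is 800 nM, with an estimated range from 150 nM to 4000 nM.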

Compound 3, half-maximal inhibitory concentration: 280 nM
Compound 3: the middle estimate sits 2.9-fold (0.46 log units) above what was measured; measured number inside the range.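

In this assay compound 1 stands at "not determined" (no result reported) and so offers no number to set against compound 3, which means no step can be read between them. As far as these compounds go, what the swap from cyclohexyl to 3-methylphenyl does to inhibition stays open. No further evidence bears on this result.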